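The compounds below may be only part of what the source reports. "The series", "measured", "known", "first", "only" and "open" are said of these compounds alone.

Three measured compounds share one core and differ in only two places. Compound 1 `CC1=C(C(=O)NC(C)C)C(c2ccoc2)NC(=O)N1` carries an isopropylamino group on a carbonyl carbon and a furan-3-yl group on a saturated ring carbon. In an assay on membranes from HEK293 cells for displacement of a labelled ligand from adenosine receptor A2b (Homo sapiens), read by scintillation counting, with a stated time of 30 min, tested at 1 uM (a lower number here means less inhibition, a higher number more inhibition at the concentration tested (going by the name of the read-out)), compound 1 gives 3%. Compound 2 `CCN(CC)C(=O)C1=C(C)NC(=O)NC1c1ccoc1` differs from it by diethylamino in place of isopropylamino on a carbonyl carbon; the step of a number 9 percentage points higher from compound 1 to compound 2 (within the scatter), and compound 2 gives 12%. Compound 3 `CC1=C(C(=O)NC(C)C)C(c2cccs2)NC(=O)N1` differs from compound 1 by thiophen-2-yl in place of furan-3-yl on a saturated ring carbon; this step a number 37 percentage points higher from compound 1 to compound 3 (beyond the scatter), and compound 3 gives 40%, the highest of the three numbers, its steps to compound 1 and compound 2 both beyond the scatter.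

Compound 4 `CCN(CC)C(=O)C1=C(C)NC(=O)NC1c1cccs1` is not yet measured. It differs from compound 3 by diethylamino in place of isopropylamino on a carbonyl carbon, the same change that turned compound 1 into compound 2, at a place described in identical words, but on the core of compound 3, whose difference from the core of compound 1 was described just above. The earlier step of a number 9 percentage points higher from compound 1 to compound 2 (within the scatter) stayed within the scatter. On that basis the step expected for compound 4 is a number 5 percentage points higher from compound 3 to compound 4 (within the scatter). The estimated value for compound 4 in this assay is 45%, expected to fall between 25% and 65%.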

Compound 4, a percentage reported as inhibition, at one concentration (the size of the read-out at that concentration, not a potency): 22%
For compound 4 the middle estimate is 23 percentage points above the measured one; the whole stated range lies above it.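

In this assay the change to diethylamino from isopropylamino gives a number 18 percentage points lower from compound 3 to compound 4 (beyond the scatter), and this change does not carry over unaltered from one core to the other: the same change on two cores in this assay, a number 9 percentage points higher (within the scatter) from compound 1 to compound 2 and a number 18 percentage points lower (beyond the scatter) from compound 3 to compound 4, 27 percentage points apart, beyond the scatter of two such steps

The change to thiophen-2-yl from furan-3-yl gives a number 10 percentage points higher from compound 2 to compound 4 (within the scatter), so its size also depends on which amino group sits on the carbonyl carbon: the same change on two cores in this assay, a number 37 percentage points higher (beyond the scatter) from compound 1 to compound 3 and a number 10 percentage points higher (within the scatter) from compound 2 to compound 4, 27 percentage points apart, beyond the scatter of two such steps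

In these four compounds, then, the two changes cannot simply be added together to predict the result, but this square of compounds, each tested at a single concentration, does not show why the steps differ or whether the same would hold on any other core.

The compounds shown leave open how a longer chain on the amide nitrogen, such as n-butylamino, would behave with either the furan-3-yl or the thiophen-2-yl group. They also leave open whether a phenyl group on the saturated ring carbon would respond to the same change of amino group.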